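The source may hold more compounds than are shown below. What is called first, only, known or untested is meant among the compounds shown, and "the series" means these compounds.

Working notes on the series. Compound 1 `CC(=O)c1ccc(OCC(=O)Nc2cccc(NC(=O)c3ccc(N(C)C)cc3)c2)cc1F`, compound 2 `Cc1c(OCC(=O)Nc2cccc(NC(=O)c3ccc(N(C)C)cc3)c2)ccc2c(=O)ccoc12` and compound 3 `CCCC(=O)Nc1cccc(NC(=O)COc2ccc3c(=O)ccoc3c2)c1` share a common core and have been measured in an assay on isolated protein for inhibition of Rho-associated protein kinase 2 (Homo sapiens), read by scintillation counting, radiometric assay and 33P incorporation, with a stated time of 40 min, in the presence of a further agent that is not named here; on this read-out higher numbers stand for weaker inhibition and lower numbers for stronger inhibition. Compound 1 gives 98 nM, compound 2 gives 4160 nM, and compound 3 gives 176 nM. Among the three numbers compound 3 stands second highest: its gap to compound 1 lies within the scatter of repeated measurements, so the two are read as alike, while compound 2 sits beyond the scatter on the side of weaker inhibition.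

Compound 4 `O=C(COc1ccc2c(=O)ccoc2c1)Nc1cccc(NC(=O)c2ccc(Br)cc2)c1` has not yet been measured. It differs from compound 3 in one place: 4-bromophenyl in place of propyl on a carbonyl carbon. Going by the values given here, no pair of measured compounds carries this same change, so its size is not known from the data. Compound 1 also bears an aromatic ring on that carbonyl carbon and gives 98 nM in this assay, a number alike to that of compound 3, which argues against a step beyond the scatter. The step from compound 3 to compound 4 is therefore expected to be small, a 1.6-fold lower number from compound 3 to compound 4 (0.20 log units; within the scatter), toward a lower number if anything. Compound 4 is estimated at 110 nM, with a range from 35 nM to 400 nM.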

Compound 4, half-maximal inhibitory concentration: 49 nM
Estimate against measurement, compound 4: 2.2-fold (0.35 log units) above, within the range that was stated.
By their numbers in this assay, from the lowest: compounds 4, 1 and 3 (each within the scatter of the next, the first and the last beyond it); then compound 2.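

In this assay, the carbonyl carbon on the amide-type nitrogen is now shown to be a place where a single change moves the number: 4-bromophenyl in place of propyl gives a 3.6-fold lower number from compound 3 to compound 4 (0.56 log units; beyond the scatter), a modest step. Going by these compounds alone, the earlier compounds included no pair differing only here, so they gave no size for any change at this place; this step is the first that can be read from one change alone. Nothing measured here bears on the reason for the step.

Within the data shown here, the single step does not separate the contribution of the six-membered aromatic ring from that of the bromine, and plain phenyl or 4-chlorophenyl on the same carbonyl carbon would divide the two. Also open, from the compounds shown here alone, is how far the trend runs in other directions on this carbon, for example with a longer alkyl chain, a cyclohexyl ring or a piperidine ring in place of the propyl of compound 3.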